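From furan-2-yl to pyridin-4-yl in a cytotoxic pair

This account rests on a few compounds, and the source may have more. Where it says the series, first, only, none or still open, it means among the compounds named here.

In a functional assay on HCT-15 cells (Homo sapiens) for cytotoxicity, read by ELISA, with a stated time of 2 days (a higher number here means a weaker inhibitor, a lower number a stronger inhibitor), compound 1 (`Oc1cccc(-c2cc(-c3ccccc3)nc(-c3ccncc3)c2)c1`) gives 18700 nM, while compound 2 (`Oc1ccc(-c2cc(-c3ccccc3)nc(-c3ccco3)c2)cc1`) gives 5100 nM. Compound 2 therefore holds the lower of the two numbers, and the gap between them lies beyond the scatter. Compound 3 (`Oc1ccc(-c2cc(-c3ccccc3)nc(-c3ccncc3)c2)cc1`) has pyridin-4-yl in place of furan-2-yl on an aromatic carbon, next to the ring nitrogen of the core: pyridin-4-yl in place of furan-2-yl on an aromatic carbon. Among the compounds with values here, no measured pair isolates this exchange. Within the data shown here, the only guide is compound 1, which also carries pyridin-4-yl and gives 18700 nM, though its hydroxyphenyl group differs from that of compound 3. On that single value, a modest step toward a higher number, meaning weaker inhibition, is expected a 2.2-fold higher number from compound 2 to compound 3 (0.33 log units; beyond the scatter). For compound 3 the estimated value is 11000 nM, with an expected range of 3500 nM to 30000 nM.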

Compound 3, half-maximal inhibitory concentration: 11700 nM
For compound 3 the middle estimate is 1.1-fold (0.03 log units) below the measured one; the measured number falls inside the stated range.
By their numbers in this assay, from the lowest: compound 2; then compounds 3 and 1 (each within the scatter of the next).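

In this assay, the exchange of furan-2-yl for pyridin-4-yl, on the aromatic carbon next to the ring nitrogen, now stands isolated with the 4-hydroxyphenyl group held fixed, and it gives a 2.3-fold higher number from compound 2 to compound 3 (0.36 log units; beyond the scatter). With pyridin-4-yl at this position, the second pair does not separate 4-hydroxyphenyl from 3-hydroxyphenyl: a 1.6-fold lower number from compound 1 to compound 3 (0.20 log units; within the scatter), which the scatter cannot distinguish from no difference. Nothing available offers an explanation for the step at this position.

The compounds shown leave open whether the step seen here would hold with 3-hydroxyphenyl in place of 4-hydroxyphenyl. They also cannot tell how another ring at this position, such as thiophen-2-yl or pyridin-3-yl, or an amine, would compare with furan-2-yl.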